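Amidine replacing methanesulfonamidomethyl on the pendant phenyl

The source may hold more compounds than are shown below. What is called first, only, known or untested is meant among the compounds shown, and "the series" means these compounds.

Compound 1, `Cn1nc2c(=O)n(CC3(O)CCN(Cc4ccc(-c5ccco5)cc4Cl)CC3)cnc2c1-c1ccc(CNS(C)(=O)=O)cc1`, gives 65.3 nM in an assay on isolated protein for inhibition of ubiquitin carboxyl-terminal hydrolase 7 (Homo sapiens), with stated times of 30 min and 2 h; on this read-out higher numbers stand for weaker inhibition and lower numbers for stronger inhibition.
Compound 2, `Cn1nc2c(=O)n(CC3(O)CCN(Cc4ccc(C5=CCCC5)cc4Cl)CC3)cnc2c1-c1ccc(CN)cc1`, gives 76.9 nM in this assay.
Compound 3, `Cn1nc2c(=O)n(CC3(O)CCN(Cc4ccc(-c5cnco5)cc4Cl)CC3)cnc2c1-c1ccc(CN)cc1`, gives 71.6 nM in this assay.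

Compound 1 has the lowest of the three numbers, but its gaps to compound 3 and to compound 2 both lie within the scatter, so the three compounds are not separable on this read-out. Among the measured compounds shown here, the one step with a single change, a 1.1-fold lower number from compound 2 to compound 3 (0.03 log units; within the scatter), concerns the group on the chlorophenyl ring and is within the scatter.

Compound 4, `Cn1nc2c(=O)n(CC3(O)CCN(Cc4ccc(-c5ccco5)cc4Cl)CC3)cnc2c1-c1ccc(C(=N)N)cc1`, differs from compound 1 in the group para to the shared core: a group of 3 heavy atoms (1 carbon, 2 nitrogen; no ring) in place of a group of 6 heavy atoms (2 carbon, 1 nitrogen, 2 oxygen, 1 sulfur; no ring), on an aromatic carbon. For the measured compounds named here, no measured step touches this position; compounds 1, 2 and 3 carry different groups there and in the shared core region, and all sit within the scatter of each other. The change from compound 1 to compound 4 is therefore expected to give no step beyond the scatter in this assay, expressed as a 1.1-fold higher number from compound 1 to compound 4 (0.03 log units; within the scatter). Compound 4 is estimated at 70 nM, within 25 nM to 200 nM.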

Compound 4, half-maximal inhibitory concentration: 87.5 nM
Beside the measured number, compound 4's estimate is 1.3-fold (0.10 log units) below it, and the stated range covers the measured number.
By their numbers in this assay, from the lowest: compounds 1, 3, 2 and 4 (each within the scatter of the next).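

In this assay the position now has its first single-place comparison, with a 1.3-fold higher number from compound 1 to compound 4 (0.13 log units; within the scatter) as the printed step, so the exchange of (methanesulfonamido)methyl for the group of 3 heavy atoms on this aromatic carbon gives no step beyond the scatter. The two groups differ in heavy atoms, double bonds outside aromatic rings, and hydrogen-bond donor and acceptor counts, yet these differences do not separate compound 1 from compound 4 on this read-out. No measurement at hand offers a reason for this result.

From the compounds shown here alone, whether other groups here, such as a carboxylic acid or a longer aminoalkyl chain, also stay within the scatter remains open. Going by these compounds, it is also open whether this exchange behaves alike with 1,3-oxazol-5-yl or cyclopent-1-en-1-yl on the chlorophenyl ring.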